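A few compounds are considered here, and "the series" means these few. Any claim that something is new, unique, unknown or untested is made for them only; others in the source may bear on it.

Compound 1, `Oc1ccc(-c2cc(-c3ccc(Cl)cc3)nc(-c3ccsc3)c2)cc1`, gives 5490 nM. Compound 2, `Oc1ccc(-c2cc(-c3ccc(Cl)cc3)nc(-c3ccco3)c2)cc1`, gives 6260 nM. Compound 3, `Oc1cccc(-c2cc(-c3ccsc3)nc(-c3ccccc3Cl)c2)c1`, gives 2440 nM.

These three compounds were all tested in a functional assay on T47D cells (Homo sapiens) for cytotoxicity, read by CCK-8 assay and cell counting, with a stated time of 2 days; a higher number here means a weaker inhibitor, a lower number a stronger inhibitor. Compound 1 and compound 2 share one core and differ in a single group: furan-2-yl in place of thiophen-3-yl on an aromatic carbon. The measured step for this change, a 1.1-fold higher number from compound 1 to compound 2 (0.06 log units; within the scatter), is small enough to count as no real change. Compound 3 is built from the same atoms as compound 1 but joined differently; the difference between the two cores is not broken down here. Compound 3 gives the lowest number of the three, and its gaps to compound 1 and compound 2 lie beyond the usual scatter, so among these it is the strongest inhibitor.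

Compound 4, `Oc1cccc(-c2cc(-c3ccco3)nc(-c3ccccc3Cl)c2)c1`, has not yet been measured. It is related to compound 3 by furan-2-yl in place of thiophen-3-yl on an aromatic carbon. This is the same kind of change as that from compound 1 to compound 2, though not the same: around the place, compound 3 has the group meta to a 2-chlorophenyl group and meta to a 3-hydroxyphenyl group, where compound 1 has it meta to a 4-chlorophenyl group and meta to a 4-hydroxyphenyl group. Because a 1.1-fold higher number from compound 1 to compound 2 (0.06 log units; within the scatter) was within the scatter, the expected step from compound 3 to compound 4 is a 1.1-fold higher number from compound 3 to compound 4 (0.04 log units; within the scatter), also within the scatter. Compound 4 is therefore estimated to give 2700 nM in this assay, with a likely range from 1400 nM to 5500 nM.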

Compound 4, half-maximal inhibitory concentration: 2010 nM
The estimate for compound 4 lay 1.3-fold (0.13 log units) above the measured number; measured number inside the range.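

In this assay, putting furan-2-yl in place of thiophen-3-yl gives a 1.2-fold lower number from compound 3 to compound 4 (0.08 log units; within the scatter), so on this second core the swap again makes no measurable difference. The two steps agree, and in this small set the swap carries from one core to the other as a change with no visible effect: the same change on two cores in this assay, a 1.1-fold higher number (0.06 log units; within the scatter) from compound 1 to compound 2 and a 1.2-fold lower number (0.08 log units; within the scatter) from compound 3 to compound 4, 1.4-fold (0.14 log units) apart, within the scatter of two such steps. This does not show that either ring is better than the other, since both steps are too small to give a direction, and two cores cannot show that the same would hold on a third core or say why the two rings behave alike here.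

Compound 1 carries a 4-chlorophenyl and a 4-hydroxyphenyl group, whereas compound 3 carries a 2-chlorophenyl and a 3-hydroxyphenyl group, so the compounds shown leave open what each of these two differences does on its own. They also leave open what happens at this place on the core with something other than these two five-membered aromatic rings, such as an amine or a carboxylic acid.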